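This account rests on a few compounds, and the source may have more. Where it says the series, first, only, none or still open, it means among the compounds named here.

In an assay on Sf9 cells for inhibition of protein deacetylase HDAC6 (Homo sapiens), read by fluorescence, with a stated time of 40 min (on this read-out lower numbers stand for stronger inhibition and higher numbers for weaker inhibition), compound 3 `O=C(NO)c1ccc(NCc2nc(-c3ccccc3)nn2-c2ccc(F)cc2)cc1` gives 274 nM. Of the measured compounds, compound 1 `O=C(NO)c1ccc(NCc2nc(-c3ccc(Cl)cc3)nn2-c2ccccc2)cc1` gives 181 nM and compound 2 `O=C(NO)c1ccc(NCc2nc(-c3cc4ccccc4s3)nn2-c2ccccc2)cc1` gives 324 nM, so compound 3 lies within the scatter of both. Compound 4 `O=C(NO)c1ccc(NCc2nc(-c3ccccc3)nn2-c2ccccc2)cc1` differs from compound 3 by hydrogen in place of fluoro on an aromatic carbon. Among the compounds with values here, the only measured step, a 1.8-fold higher number from compound 1 to compound 2 (0.25 log units; within the scatter), concerns the other aryl group rather than the ring that carries the fluoro, and it stayed within the scatter; no measured pair bears directly on this change. With all three numbers close together, no shift beyond the scatter is expected in this assay. Compound 4 is therefore expected to give about 250 nM, between 120 nM and 550 nM. The expected step, a 1.1-fold lower number from compound 3 to compound 4 (0.04 log units; within the scatter), should stay within the scatter.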

Compound 4, half-maximal inhibitory concentration: 112 nM
Compound 4: middle estimate off by 2.2-fold (0.35 log units), on the high side; measured number outside the range, below it.
By their numbers in this assay, from the lowest: compounds 4, 1, 3 and 2 (each within the scatter of the next, the first and the last beyond it).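

In this assay, hydrogen in place of fluoro gives a 2.4-fold lower number from compound 3 to compound 4 (0.39 log units; beyond the scatter), so this position responds to a single-atom change by more than the scatter, which no earlier step had shown. At the other aryl group, phenyl in place of 1-benzothiophen-2-yl gives a 2.9-fold lower number from compound 2 to compound 4 (0.46 log units; beyond the scatter), also beyond the scatter, whereas hydrogen in place of chloro gives a 1.6-fold lower number from compound 1 to compound 4 (0.21 log units; within the scatter), which stays within it. Nothing available offers a reason for these steps. The compounds shown leave open how a chloro, a methoxy group or an amine at the fluoro position would compare with hydrogen and fluoro. They also leave open whether fluoro has the same effect when the other aryl group carries chloro.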